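The source may report more compounds than this note shows. Statements on the series, on what has been measured and on what is new or still open speak of the compounds shown alone.

The three measured compounds were all tested in a functional assay on HeLa cells (Homo sapiens) for inhibition, read by CCK-8 assay, with a stated time of 48 h; a higher number here means a weaker inhibitor, a lower number a stronger inhibitor. Compound 1 `O=[N+]([O-])c1ccc(NC(=S)NCCNS(=O)(=O)c2ccc(-c3ccccc3OCc3ccccc3)s2)cc1` gives 7100 nM in this assay. Compound 2 `Cc1ccc(-c2ccsc2S(=O)(=O)NCCNC(=S)Nc2ccc([N+](=O)[O-])cc2)c(Oc2ccc(O)c(O)c2)c1` gives 6800 nM in this assay, the lowest of the two numbers, but compound 1 sits within the scatter of it, so the two cannot be put in order. Compound 3 `O=C(NCCNS(=O)(=O)c1ccc(-c2ccccc2Oc2ccc(O)c(O)c2)s1)Nc1cc(C(F)(F)F)cc(C(F)(F)F)c1` gives only a limit of the assay, > 20000 nM. That is the limit of > 20000 nM in this assay, at which 1 of the 3 values shown sits.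

Compound 4 `Cc1ccc(-c2ccsc2S(=O)(=O)NCCNC(=O)Nc2ccc([N+](=O)[O-])cc2)c(Oc2ccc(O)c(O)c2)c1` has not yet been measured in this assay. It differs from compound 2 in one place: a group of 12 heavy atoms (7 carbon, 2 nitrogen, 3 oxygen; one six-membered aromatic ring of carbon only) in place of a group of 12 heavy atoms (7 carbon, 2 nitrogen, 2 oxygen, 1 sulfur; one six-membered aromatic ring of carbon only), on an amine nitrogen. For the measured compounds named here, no pair of measured compounds differs in this one place alone, so the size of this step has not been seen in the data. Compound 3 also carries a carbamoyl group, yet it differs from compound 2 in other places as well, and its value is a limit. The author expects a small weakening, possibly no more than the scatter, as a 1.5-fold higher number from compound 2 to compound 4 (0.17 log units; within the scatter). Compound 4 is therefore estimated at 10000 nM in this assay, within a range from 4000 nM to 25000 nM.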

Compound 4, half-maximal inhibitory concentration: > 20000 nM
Compound 4 gave a limit, no number; the forecaster's own chance of this, stated with the estimate: 25%; at least 2.0-fold (0.30 log units) between middle value and limit.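

In this assay, the (4-nitrophenyl)carbamoyl group on the amine nitrogen, which has oxygen where the group it replaces has sulfur, gives an at least 2.9-fold higher number from compound 2 to compound 4 (0.46 log units; beyond the scatter). For the compounds shown here, this is the first measured step at this position, and it shows that this exchange alone, with the rest of the structure unchanged, carries the value beyond the scatter. The value of compound 4 is a limit and not a number, so the step has a lower bound but no known full size: the limit of > 20000 nM in this assay, at which 2 of the 4 values shown sit.

The compounds shown leave open whether the same exchange would have a similar effect on the core of compound 1. They also leave open how a different group on this amine nitrogen, such as a sulfonyl or a cyanoguanidine, would compare with compound 2.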